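A few compounds are considered here, and "the series" means these few. Any claim that something is new, unique, unknown or untested is made for them only; others in the source may bear on it.

Measured so far:
compound 1, `COc1ccc(N(CC(=O)NCCC[Se]c2ccccc2)C(=O)c2ccccc2)cc1`, in a physicochemical assay for lipophilicity, read by HPLC, measured as octanol-water partition (a lower number here means a more polar compound, a higher number a more lipophilic compound), gives 3.1.
compound 2, `COc1ccc(N(CC(=O)NCCCSc2ccccc2)C(=O)CNC(=O)OC(C)(C)C)cc1`, in this assay gives 3.12.

Among the measured compounds shown here, compound 2 is one of only two measured compounds here, and its reading sits within the scatter of the reading for compound 1, so the two cannot be told apart by this assay; neither stands above the other.

The step to be followed goes from compound 2 to compound 3, `COc1ccc(N(CC(=O)NCCCSc2ccccc2)C(=O)c2ccccc2)cc1`, which has not yet been measured in this assay. The change is phenyl in place of ((tert-butoxycarbonyl)amino)methyl on a carbonyl carbon; cut one bond further out, it reads as (((tert-butoxycarbonyl)amino)methyl)carbonyl to benzoyl. For the measured compounds named here, nothing among the measured pairs shows what this particular swap does, so its size can only be guessed. Compound 1 also carries a benzoyl, and since compound 1 gives 3.1, a value close to that of compound 2 is plausible, with a modest rise as the likelier direction. For compound 3 the expected step from compound 2 is a number 0.28 log units higher from compound 2 to compound 3 (within the scatter), and its estimated value is 3.4, in the range 3 to 3.8.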

Compound 3, partition coefficient: 3.1
The estimate for compound 3 lay 0.30 log units above the measured number, and the stated range covers the measured number.
By their numbers in this assay, from the lowest: compounds 1, 3 and 2 (each within the scatter of the next).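

In this assay, phenyl in place of ((tert-butoxycarbonyl)amino)methyl on a carbonyl carbon gives a number 0.02 log units lower from compound 2 to compound 3 (within the scatter), so at this position, a group of 9 heavy atoms with no ring, 1 hydrogen-bond donor and 2 hydrogen-bond acceptors and a group of 6 carbon atoms in one aromatic ring with neither donor nor acceptor cannot be told apart by this measurement. Sulfur in place of selenium, in the group on a saturated chain carbon three bonds along the chain from an amide-type nitrogen, gives no change at the digits printed from compound 1 to compound 3 (within the scatter), so this second single change also leaves no readable difference, and compound 3 now links the two earlier compounds through one change each. Nothing available here offers an explanation for either result.

On these data alone, it remains open whether a different group on the same carbonyl carbon, such as an aminomethyl group or one ending in a carboxylic acid, would give a step beyond the scatter. A longer chain between the amide-type nitrogen and the sulfur is also untested by these compounds.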